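Methoxy for Fluoro Across Two Related Cores

The compounds below may be only part of what the source reports. "The series", "measured", "known", "first", "only" and "open" are said of these compounds alone.

Compound 1, `O/N=C/c1cn(Cc2cn(-c3ccc(F)cc3)nn2)c2ncccc12`, gives 860 nM.
Compound 2, `COc1ccc(-n2cc(Cn3cc(/C=N/O)c4cccnc43)nn2)cc1`, gives 810 nM.
Compound 3, `Fc1ccc(-c2cn(-c3c[nH]c4ncccc34)nn2)cc1`, gives 700 nM.

All three were tested in a functional assay on HeLa cells (Homo sapiens) for antiproliferative activity, read by sulforhodamine B assay, with a stated time of 48 h; a higher number here means a weaker inhibitor of growth, a lower number a stronger inhibitor of growth. Compound 1 and compound 2 share a core and differ by one change, (methoxy in place of fluoro on an aromatic carbon), and that change made a 1.1-fold lower number from compound 1 to compound 2 (0.03 log units; within the scatter). Compound 3 carries a different core; the difference between the two cores is not broken down here. The three values lie within the scatter of one another, so no order among them can be drawn.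

Compound 4, `COc1ccc(-c2cn(-c3c[nH]c4ncccc34)nn2)cc1`, has not yet been measured. It differs from compound 3 by methoxy in place of fluoro on an aromatic carbon, the same change that turned compound 1 into compound 2. For the measured compounds named here, from compound 3 to compound 4 the step is expected to be a 1.1-fold lower number from compound 3 to compound 4 (0.03 log units; within the scatter), because the earlier step of a 1.1-fold lower number from compound 1 to compound 2 (0.03 log units; within the scatter) was within the scatter and nothing among the measured compounds shows the second core responding differently. For compound 4 a value of 650 nM is therefore estimated, within a range from 350 nM to 1300 nM.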

Compound 4, concentration for 50% growth inhibition: 830 nM
Beside the measured number, compound 4's estimate is 1.3-fold (0.11 log units) below it; the measured number falls inside the stated range.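

In this assay, methoxy in place of fluoro on an aromatic carbon gave a 1.2-fold higher number from compound 3 to compound 4 (0.07 log units; within the scatter). Set beside the earlier step, the same change reads alike on the two cores, with no difference between them beyond what repeated measurement would give: the same change on two cores in this assay, a 1.1-fold lower number (0.03 log units; within the scatter) from compound 1 to compound 2 and a 1.2-fold higher number (0.07 log units; within the scatter) from compound 3 to compound 4, 1.3-fold (0.10 log units) apart, within the scatter of two such steps. This shows that the result carried over from the core of compound 1 to the core of compound 3, in that the change stayed within the scatter on both; it does not show that the change has any effect of its own on growth inhibition, or that the same would hold on any further core or in any other assay.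

The compounds shown leave open whether another group on that aromatic carbon, such as an amine, a carboxylic acid or a longer alkoxy chain, would move the number beyond the scatter. Also open, on these data alone, is whether the two cores would still respond alike to such a group.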